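Trifluoromethyl in Place of Methyl on a Weak Acetyl Compound

The source may report more compounds than this note shows. Statements on the series, on what has been measured and on what is new or still open speak of the compounds shown alone.

Compound 3 `CC(=O)c1cccn1C1=CC(C)(C)Oc2ccc(C#N)cc21` carries an acetyl group on the shared core. In a functional assay (Trachealis) for inhibition, with Cavia porcellus as the target (on this read-out lower numbers stand for stronger inhibition and higher numbers for weaker inhibition), compound 3 gives > 20000 nM, which is a limit of the assay and not a number. Compound 2 `CC1(C)C=C(n2cccc2)c2cc(C#N)ccc2O1`, with hydrogen in that place, gives 4080 nM in this assay. Compound 1 `CCc1cccn1C1=CC(C)(C)Oc2ccc(C#N)cc21`, with ethyl there, gives > 20000 nM, also a limit. The step of an at least 4.9-fold higher number from compound 2 to compound 3 (0.69 log units; beyond the scatter) shows acetyl weakening inhibition, while a step that the two limits leave unreadable from compound 1 to compound 3 cannot be read because the limit of > 20000 nM in this assay, at which 2 of the 3 values shown sit, hides both ends. Compound 4 `CC1(C)C=C(n2cccc2C(=O)C(F)(F)F)c2cc(C#N)ccc2O1` differs from compound 3 by trifluoromethyl in place of methyl on a carbonyl carbon. Going by the values given here, no measured step touches the carbonyl carbon, so nothing in hand bears directly on this change; the expected step is a number no higher from compound 3 to compound 4 (the limit leaves the size open). Compound 4 is therefore estimated at 20000 nM, within 5000 nM to 80000 nM.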

Compound 4, half-maximal inhibitory concentration: 690 nM
Estimate against measurement, compound 4: 29-fold (1.46 log units) above; measured number outside the range, below it.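

Among the groups shown on this aromatic carbon, ethyl and acetyl both weaken inhibition compared with hydrogen, but (trifluoromethyl)carbonyl strengthens it in this assay, with a 5.9-fold lower number from compound 2 to compound 4 (0.77 log units; beyond the scatter). The carbonyl alone does not bring this gain, as trifluoromethyl in place of methyl on the carbonyl carbon gives an at least 28-fold lower number from compound 3 to compound 4 (1.46 log units; beyond the scatter), and replacing ethyl gives an at least 28-fold lower number from compound 1 to compound 4 (1.46 log units; beyond the scatter). The last two sizes are open on one side, as compound 1 and compound 3 stand at a limit of the assay: the limit of > 20000 nM in this assay, at which 2 of the 4 values shown sit. The compounds shown leave open how difluoromethyl or pentafluoroethyl on the carbonyl carbon would compare with trifluoromethyl. They also leave open how an amide or a carboxylic acid would read on the aromatic carbon.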